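Methyl in Place of Chloro: Compound 3 to Compound 4

The source may report more compounds than this note shows. Statements on the series, on what has been measured and on what is new or still open speak of the compounds shown alone.

Compound 1 `COc1ccc([C@@H]2CC(=O)c3c(O)cc(OCc4cn(Cc5ccccc5C#N)nn4)cc3O2)cc1O` gives 14600 nM in a functional assay on RAW264.7 cells (Mus musculus) for inhibition, read by Griess assay, with stated times of 2 h and 24 h; on this read-out lower numbers stand for stronger inhibition and higher numbers for weaker inhibition.
Compound 2 `COc1ccc([C@@H]2CC(=O)c3c(O)cc(OCc4cn(C5CCCC5)nn4)cc3O2)cc1O` gives 10500 nM in this assay.
Compound 3 `COc1ccc([C@@H]2CC(=O)c3c(O)cc(OCc4cn(Cc5cccc(Cl)c5)nn4)cc3O2)cc1O` gives 18200 nM in this assay.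

Of the three numbers, compound 3 has the highest, yet neither a 1.2-fold higher number from compound 1 to compound 3 (0.10 log units; within the scatter) nor a 1.7-fold higher number from compound 2 to compound 3 (0.24 log units; within the scatter) rises above the scatter, so the three compounds are not separated by these data. Compound 4 `COc1ccc([C@@H]2CC(=O)c3c(O)cc(OCc4cn(Cc5cccc(C)c5)nn4)cc3O2)cc1O` differs from compound 3 in one place: methyl in place of chloro on an aromatic carbon. Among the compounds with values here, no measured step swaps one small group for another on that aromatic ring; the two steps that reach compound 3 exchange the whole group on the aromatic nitrogen, and both stay within the scatter. A methyl in place of chloro is therefore expected to give no step beyond the scatter, a 1.1-fold lower number from compound 3 to compound 4 (0.06 log units; within the scatter). Compound 4 is expected to give 16000 nM, with a range from 8000 nM to 32000 nM.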

Compound 4, half-maximal inhibitory concentration: 17400 nM
Estimate against measurement, compound 4: 1.1-fold (0.04 log units) below, and the stated range covers the measured number.
By their numbers in this assay, from the lowest: compounds 2, 1, 4 and 3 (each within the scatter of the next).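

Swapping one small group on this aromatic ring gives a 1.0-fold lower number from compound 3 to compound 4 (0.02 log units; within the scatter) in this assay and so does not separate methyl from chloro at this place. Exchanging the whole group on the aromatic nitrogen also stays within the scatter, with a 1.7-fold higher number from compound 2 to compound 4 (0.22 log units; within the scatter) and a 1.2-fold higher number from compound 1 to compound 4 (0.08 log units; within the scatter) leaving all four compounds unseparated. No measured evidence here bears on this result.

Going by these compounds, whether an amine, a carboxylic acid or a longer chain at this place on the ring would shift the number beyond the scatter remains open.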